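Working notes: phenyl for pyridin-3-yl on the thioether carbon

The source may hold more compounds than are shown below. What is called first, only, known or untested is meant among the compounds shown, and "the series" means these compounds.

Of the compounds shown here, two have been measured in an assay on isolated protein for inhibition of aldehyde dehydrogenase 1A1 (Homo sapiens); a lower number here means a stronger inhibitor, a higher number a weaker inhibitor. Compound 1 `CC(Sc1nc2nn(CC3COC3)cc2c(=O)n1-c1ccccc1)c1ccccc1` gives 100 nM in this assay. Compound 2 `CC(Sc1nc2nn(C3COC3)cc2c(=O)n1-c1ccccc1)c1cccnc1` gives 118 nM in this assay. Among the compounds with values here, compound 2 has the highest of the two numbers so far, and the nearest is compound 1, whose number lies within the scatter of that of compound 2; these two differ in two places at once, so no single step between them can be read, and the pair shows only that both numbers sit close together.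

Compound 3 `CC(Sc1nc2nn(C3COC3)cc2c(=O)n1-c1ccccc1)c1ccccc1` has not yet been measured. It differs from compound 2 in one place: phenyl in place of pyridin-3-yl on a saturated chain carbon bound to a saturated chain carbon and a sulfur. Compound 1 also carries a phenyl at this carbon, but its chain on the ring nitrogen is longer, so compound 1 gives no direct read of this change.

Within the data shown here, no measured step of this kind is available. The expected step from compound 2 to compound 3 is a 1.3-fold lower number from compound 2 to compound 3 (0.12 log units; within the scatter), a change not expected to exceed the scatter. For compound 3 the estimate in this assay is 90 nM, expected to fall between 45 nM and 180 nM.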

Compound 3, half-maximal inhibitory concentration: 109 nM
Compound 3: the middle estimate sits 1.2-fold (0.08 log units) below what was measured, and the stated range covers the measured number.
By their numbers in this assay, from the lowest: compounds 1, 3 and 2 (each within the scatter of the next).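

In this assay, the change at the saturated chain carbon bound to a saturated chain carbon and a sulfur can now be read alone: with phenyl in place of pyridin-3-yl, the step is a 1.1-fold lower number from compound 2 to compound 3 (0.03 log units; within the scatter) and stays within the scatter. In this pair, then, the hydrogen-bond acceptor counted for pyridin-3-yl can be absent without a readable change in the number. The second single change, oxetan-3-yl in place of (oxetan-3-yl)methyl on an aromatic nitrogen, gives a 1.1-fold higher number from compound 1 to compound 3 (0.04 log units; within the scatter) and also stays within the scatter, so the two changes that could not be separated in the first pair now each show no readable effect. No evidence bears on why either step is this small.

The compounds shown carry only two aromatic rings on this carbon and only two oxetane-bearing groups on the aromatic nitrogen, so the limits of this tolerance remain undefined. Going by these compounds, it remains open whether a saturated ring such as cyclohexyl at the carbon, or an amine or a carboxylic acid in the chain on the aromatic nitrogen, would move the number beyond the scatter.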